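Nitro in place of methoxy on the aryl-triazole acetamides

The compounds below may be only part of what the source reports. "The series", "measured", "known", "first", "only" and "open" are said of these compounds alone.

compound 1, `CCOC(=O)c1sc(NC(=O)Cn2cc(-c3ccc(OC)cc3)nn2)nc1C`: 2330 nM
compound 2, `O=C(Cn1cc(-c2ccc([N+](=O)[O-])cc2)nn1)Nc1nc2ccccc2s1`: 3280 nM
compound 3, `COc1ccc(-c2cn(CC(=O)Nc3nc4ccccc4s3)nn2)cc1`: 1330 nM

All three were run in a functional assay on BMDM cells (Mus musculus, strain C57BL/6) for inhibition, with a stated time of 2 days; a lower number here means a stronger inhibitor, a higher number a weaker inhibitor. Compound 1 and compound 3 carry the same triazole acetamide arm on different amine cores; the difference between the two cores is not broken down here. Compound 2 and compound 3 differ in one place only, (nitro in place of methoxy on an aromatic carbon), and that step reads a 2.5-fold higher number from compound 3 to compound 2 (0.39 log units; beyond the scatter). The values of compound 1 and compound 2 lie within the scatter of each other, as do those of compound 1 and compound 3.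

Compound 4, `CCOC(=O)c1sc(NC(=O)Cn2cc(-c3ccc([N+](=O)[O-])cc3)nn2)nc1C`, has not been measured. It stands to compound 1 as compound 2 stands to compound 3: nitro in place of methoxy on an aromatic carbon, the same change at the same place. Going by the values given here, the step from compound 1 is expected to be a 2.5-fold higher number from compound 1 to compound 4 (0.40 log units; beyond the scatter), because the one measured instance of this change gave a 2.5-fold higher number from compound 3 to compound 2 (0.39 log units; beyond the scatter). Compound 4 is therefore estimated at 5800 nM in this assay, with a likely range of 2600 nM to 13000 nM.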

Compound 4, half-maximal inhibitory concentration: 1840 nM
Beside the measured number, compound 4's estimate is 3.2-fold (0.50 log units) above it; the whole stated range lies above it.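

Carried to a second core, the swap of 4-methoxyphenyl to 4-nitrophenyl reads a 1.3-fold lower number from compound 1 to compound 4 (0.10 log units; within the scatter) in this assay. The two readings of the same change do not agree, so its size in this series depends on the core that carries it: the same change on two cores in this assay, a 2.5-fold higher number (0.39 log units; beyond the scatter) from compound 3 to compound 2 and a 1.3-fold lower number (0.10 log units; within the scatter) from compound 1 to compound 4, 3.1-fold (0.49 log units) apart, beyond the scatter of two such steps

This rests on one pair per core, so it does not show which feature of the cores sets the gap, nor how the change would read on any further core. On these data alone, how an amine or a carboxylic acid in place of methoxy would read on either core remains open. Also open, as far as these compounds go, is whether a chlorine there would show the same gap between cores.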